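Swapping Hydroxyamino for Allylsulfanyl on a Fused Core

This account rests on a few compounds, and the source may have more. Where it says the series, first, only, none or still open, it means among the compounds named here.

Three compounds have so far been measured in a functional assay on HeLa cells (Homo sapiens) for antiproliferative activity, read by MTT assay, with a stated time of 48 h; a lower number here means a stronger inhibitor, a higher number a weaker inhibitor:
Compound 1, `Cc1ccc(-c2nc3ccc(Cl)cc3c(=O)[nH]2)cc1`, gives 10.1 ug/mL.
Compound 2, `Cc1ccc(-c2nc3ccc(Cl)cc3c(=S)[nH]2)cc1`, gives 4.57 ug/mL.
Compound 3, `Cc1ccc(-c2nc(NO)c3cc(Cl)ccc3n2)cc1`, gives 12.7 ug/mL.

Compound 3 carries the highest number of the three. Its gap to compound 1 lies within the scatter, so those two cannot be ranked against each other; its gap to compound 2 lies beyond the scatter, with compound 2 showing the lower number. Compound 4, `C=CCSc1nc(-c2ccc(C)cc2)nc2ccc(Cl)cc12`, has not yet been measured. It differs from compound 3 in a single place: allylsulfanyl in place of hydroxyamino on an aromatic carbon. Within the data shown here, no measured pair shows this exact exchange, so nothing recorded tells its size. A modest step toward a lower number is expected, a 1.8-fold lower number from compound 3 to compound 4 (0.26 log units; within the scatter). Compound 4 is therefore estimated at 7 ug/mL, with a likely range from 2.5 ug/mL to 20 ug/mL.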

Compound 4, half-maximal inhibitory concentration: 9.66 ug/mL
Compound 4: the middle estimate sits 1.4-fold (0.14 log units) below what was measured, within the range that was stated.
By their numbers in this assay, from the lowest: compound 2; then compounds 4, 1 and 3 (each within the scatter of the next).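

The step is a 1.3-fold lower number from compound 3 to compound 4 (0.12 log units; within the scatter), so in this assay the two compounds cannot be told apart, even though allylsulfanyl is the larger group, with 4 heavy atoms against 2. On this aromatic carbon next to the ring nitrogen, the 2 hydrogen-bond donors of hydroxyamino can give way to a group with 0 without a readable change in this one assay. Nothing available explains why the two groups read alike.

Still open, on these data alone, is whether an amine or a longer chain on the same carbon would read alike, and whether propylsulfanyl, which lacks the double bond, would match allylsulfanyl.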